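From methoxy to methyl on an aromatic carbon

This account rests on a few compounds, and the source may have more. Where it says the series, first, only, none or still open, it means among the compounds named here.

In a functional assay on HeLa cells (Homo sapiens) for inhibition, read by sulforhodamine B assay (a lower number here means a stronger inhibitor, a higher number a weaker inhibitor), compound 3 (`COc1ccc(NC2=CC(=O)c3nc4n(c3C2=O)[C@H]2OC[C@@H](O)[C@H]2OC4)cc1`) gives 4780 nM and stands within the scatter of both other measured compounds: compound 1 (`CCc1ccc(NC2=CC(=O)c3nc4n(c3C2=O)[C@H]2OC[C@@H](O)[C@H]2OC4)cc1`) gives 3990 nM and compound 2 (`O=C1C=C(Nc2ccc(Br)cc2)C(=O)c2c1nc1n2[C@H]2OC[C@@H](O)[C@H]2OC1`) gives 3830 nM on the same shared core. Compound 4 (`Cc1ccc(NC2=CC(=O)c3nc4n(c3C2=O)[C@H]2OC[C@@H](O)[C@H]2OC4)cc1`) has methyl in place of methoxy on an aromatic carbon, para to a large group (methyl in place of methoxy on an aromatic carbon), so 4-methoxyphenyl becomes 4-methylphenyl. The measured steps at that place are small: ethyl to methoxy gave a 1.2-fold higher number from compound 1 to compound 3 (0.08 log units; within the scatter) and bromo to methoxy gave a 1.2-fold higher number from compound 2 to compound 3 (0.10 log units; within the scatter) and both lie within the scatter, as does a 1.0-fold lower number from compound 1 to compound 2 (0.02 log units; within the scatter) for bromo in place of ethyl. Within the data shown here, no measured compound carries methyl, so the expectation rests on these three groups alone. Given those steps, no change beyond the scatter is expected in this assay for this swap. The estimated change is a 1.2-fold lower number from compound 3 to compound 4 (0.07 log units; within the scatter) and lies within the scatter. For compound 4 the expected value is 4100 nM with an estimated range from 2300 nM to 7500 nM in this assay when it is measured.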

Compound 4, half-maximal inhibitory concentration: 3860 nM
The estimate for compound 4 lay 1.1-fold (0.03 log units) above the measured number; the measured number falls inside the stated range.
By their numbers in this assay, from the lowest: compounds 2, 4, 1 and 3 (each within the scatter of the next).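

In this assay methyl gives a 1.2-fold lower number from compound 3 to compound 4 (0.09 log units; within the scatter) against methoxy and a 1.0-fold higher number from compound 2 to compound 4 (0.00 log units; within the scatter) against bromo and a 1.0-fold lower number from compound 1 to compound 4 (0.01 log units; within the scatter) against ethyl, so a fourth group at this place on the aromatic ring stays within the scatter of the other three. Losing the oxygen and the one hydrogen-bond acceptor of methoxy thus leaves the number within the scatter, as does shortening ethyl to methyl, and across these four compounds the group para to a large group does not separate them. Nothing measured here gives a reason for this flat result. From the compounds shown here alone, whether an amine, a carboxylic acid or a longer chain at this place would move the number beyond the scatter stays open. So does whether any of the four groups is needed at all, since the compounds shown include none with plain hydrogen there.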